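This account rests on a few compounds, and the source may have more. Where it says the series, first, only, none or still open, it means among the compounds named here.

Three compounds that share one core and differ in a long chain have been tested in a functional assay on SK-MEL-5 cells (Homo sapiens) for antiproliferative activity; on this read-out lower numbers stand for stronger inhibition of growth and higher numbers for weaker inhibition of growth. Compound 1 `COCCCCCCCCCCCCCCC/C=C1\CC(CO)(COC(=O)C(C)(C)C)OC1=O` gives 1.75 ug/mL, compound 2 `COCCCCCCCCCCC/C=C1\CC(CO)(COC(=O)C(C)(C)C)OC1=O` gives 2.81 ug/mL, and compound 3 `COC(=O)CCCCCCCCCCCCCC/C=C1\CC(CO)(COC(=O)C(C)(C)C)OC1=O` gives 7.8 ug/mL. The step of a 1.6-fold higher number from compound 1 to compound 2 (0.21 log units; within the scatter) does not separate those two compounds, whereas the step of a 2.8-fold higher number from compound 2 to compound 3 (0.44 log units; beyond the scatter) puts compound 2 on the stronger side of compound 3.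

Compound 4 `CCCCCCCCC(O)CCCCCC/C=C1\CC(CO)(COC(=O)C(C)(C)C)OC1=O` has yet to be measured. Its change from compound 2 is this: 1-hydroxynonyl in place of 5-methoxypentyl on a saturated chain carbon, six bonds along the chain from a double-bonded chain carbon. For the measured compounds named here, no measured compound carries a hydroxy group on this chain, so no step speaks to the change directly. The nearest guides are chain changes further along, and the largest of these is the step of a 4.5-fold higher number from compound 1 to compound 3 (0.65 log units; beyond the scatter), which is only modest. A large shift therefore seems unlikely, though this rests on very few compounds. The estimated step is a 1.2-fold higher number from compound 2 to compound 4 (0.10 log units; within the scatter), so no clear change is expected. For compound 4 the estimated value is 3.5 ug/mL, with an expected range from 1.4 ug/mL to 8.5 ug/mL.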

Compound 4, concentration for 50% growth inhibition: > 10 ug/mL
Compound 4: no number, only a limit; the forecaster's own chance of this, stated with the estimate: 3%; at least 2.8-fold (0.45 log units) between middle value and limit.
By their numbers in this assay, from the lowest: compounds 1 and 2 (each within the scatter of the next); then compound 3. At a limit, above all of these: compound 4.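

In this assay compound 4 gives > 10 ug/mL, which is a limit and not a number: the limit of > 10 ug/mL in this assay, at which 1 of the 4 values shown sits. The 1-hydroxynonyl group, placed six bonds along the chain from a double-bonded chain carbon, brings weaker inhibition of growth, with an at least 3.5-fold higher number from compound 2 to compound 4 (0.55 log units; beyond the scatter) and an at least 5.7-fold higher number from compound 1 to compound 4 (0.75 log units; beyond the scatter). For the compounds shown here, each of the earlier compounds still gave a number, with compound 3 the highest at 7.8 ug/mL.

Going by these compounds, the true size of these steps stays unknown, and the hydroxy group arrives together with a different chain, so the two cannot be told apart. On these data alone, whether a plain nonyl chain without the hydroxy group, or an amine or a carboxylic acid on the same chain carbon, would also give weaker inhibition stays open.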